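Dropping a Chloro Group: What Happens to Paw Swelling

This account rests on a few compounds, and the source may have more. Where it says the series, first, only, none or still open, it means among the compounds named here.

Of the compounds shown here, two have been tested in a functional assay on the whole organism (strain albino) for inhibition, with Rattus norvegicus as the target, read by paw edema, with a stated time of 180 min, at a dose of 100 mg/kg by the oral route; on this read-out lower numbers stand for less inhibition and higher numbers for more inhibition at the one dose given (going by the name of the read-out). Compound 1 `Clc1ccccc1NCc1nc2ccc(Br)cc2[nH]1` gives 22.2%, and compound 2 `Clc1cccc(NCc2nc3ccc(Br)cc3[nH]2)c1` gives 16.6%. Compound 1 has the starting number for this piece, but the gap to compound 2 lies within the usual scatter of repeated measurements, so the two readings cannot be told apart on these data alone; nothing here says that one number is truly higher than the other.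

Compound 3 `Brc1ccc2nc(CNc3ccccc3)[nH]c2c1` has not yet been measured. It differs from compound 1 in one place: hydrogen in place of chloro on an aromatic carbon. Going by the values given here, because no step between two measured compounds is available, there is no direct guide to what this change does in this assay.

The two measured readings are modest and close to each other, so the expectation for compound 3 is that the step of a number 4.2 percentage points lower from compound 1 to compound 3 (within the scatter) stays small, no larger than the scatter, leaning downward if anywhere. For compound 3 the estimated value is 18%, with a range from 6% to 30%.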

Compound 3, a percentage reported as inhibition, in the whole organism at one dose (the size of the read-out at that dose, not a potency): 22.2%
Compound 3: the middle estimate sits 4.2 percentage points below what was measured, within the range that was stated.
By their numbers in this assay, from the lowest: compounds 2, 1 and 3 (each within the scatter of the next).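

Going by these compounds alone, replacing chloro with hydrogen on an aromatic carbon, ortho to a large group, gives the first direct reading of this change in this assay, and it shows no change at the digits printed from compound 1 to compound 3 (within the scatter) for this position. The same swap made on compound 2, whose chloro sits on a different carbon of the ring, gives a number 5.6 percentage points higher from compound 2 to compound 3 (within the scatter), so in these three compounds neither placement of the chloro group can be told apart from having only hydrogen on the ring. Nothing measured here offers an explanation for this result.

Going by these compounds, what stays open is whether any other group on this ring can move the reading beyond the usual scatter, for example a methoxy group, a fluorine atom or an amine, each of which could be compared directly with the hydrogen of compound 3. The readings also come from a single oral dose at a single time point, so they leave open how the inhibition would look at other doses or at other times.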